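Pyrazolopyrimidine piperazines: cytotoxicity series, thiophene replacement

A few compounds are considered here, and "the series" means these few. Any claim that something is new, unique, unknown or untested is made for them only; others in the source may bear on it.

Measured so far:
compound 1 `Brc1ccc(C(c2ccccc2)N2CCN(c3ncnc4c3cnn4-c3ccccc3)CC2)cc1`: > 25000 nM
compound 2 `c1ccc(C(c2ccncc2)N2CCN(c3ncnc4c3cnn4-c3ccccc3)CC2)cc1`: > 25000 nM

Working notes. Both measured compounds share the same core and differ only in the aryl group on the saturated chain carbon bound to an amine nitrogen in a ring and an aromatic carbon. In a functional assay on cells (Rhabdomyosarcoma cell, Homo sapiens) for cytotoxicity (on this read-out higher numbers stand for weaker inhibition and lower numbers for stronger inhibition), compound 1 gives > 25000 nM, which is a limit of the assay and not a number. In this assay compound 2 likewise gives > 25000 nM, again a limit of the assay. The step that the two limits leave unreadable from compound 1 to compound 2 therefore cannot be sized; both values sit at the limit of > 25000 nM in this assay, at which 2 of the 2 values shown sit.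

Compound 3 `Cc1ccsc1C(c1ccccc1)N1CCN(c2ncnc3c2cnn3-c2ccccc2)CC1` is not yet measured. Its change from compound 2 is 3-methylthiophen-2-yl in place of pyridin-4-yl on a saturated chain carbon bound to an amine nitrogen in a ring and an aromatic carbon. Going by the values given here, no measured step reads on this change, since the only step available, a step that the two limits leave unreadable from compound 1 to compound 2, is masked by the two limits. With nothing showing any member of the series reaching a numerical value, the expectation for compound 3 in this assay is a further limit rather than a number.

Compound 3 is estimated at 30000 nM, with a range from 10000 nM to 100000 nM. The expected step that the limit leaves unreadable from compound 2 to compound 3 is thus read as no change beyond the scatter.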

Compound 3, half-maximal inhibitory concentration: > 25000 nM
Compound 3: only a limit was reported; the forecaster's own chance of this, stated with the estimate: 80%; the middle value is on the limit's open side.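

In this assay, going by these compounds alone, compound 3 gives > 25000 nM, a limit of the assay and not a number, so its steps to compound 1 and compound 2 cannot be read and no new step follows. The compounds shown leave open whether any aryl group at this place on the shared core gives a numerical value: the limit of > 25000 nM in this assay, at which 3 of the 3 values shown sit.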